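The source may hold more compounds than are shown below. What is called first, only, known or untested is meant among the compounds shown, and "the series" means these compounds.

Measured so far:
- Compound 1, `N#CC1=C(NCCN)N(c2ccccc2)C(=O)N2CCCC12`: 27.3%
- Compound 2, `NC1=C(/C(N)=N\O)C2CCCN2C(=O)N1c1ccccc1`: 14.9%

Of the compounds shown here, two sharing one core have been tested in a functional assay on the whole organism (strain albino) for inhibition, with Rattus norvegicus as the target, read by paw edema, with a stated time of 2 h, at a dose of 0.029 mmol/kg by the oral route; a higher number here means more inhibition at the dose given (going by the name of the read-out), a lower number less inhibition. Compound 1 gives 27.3% and compound 2 gives 14.9%. Among the measured compounds shown here, of these two numbers, the one for compound 2 is the lower, and its distance from compound 1 is beyond the usual scatter, so the inhibition in this assay for compound 2 is the lower of the pair on what has been measured.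

The next compound, compound 3, `N/N=C(/N)C1=C(N)N(c2ccccc2)C(=O)N2CCCC12`, differs from compound 2 in a single spot: amino in place of hydroxy on a double-bonded nitrogen. One small group is swapped for another of the same size, and the rest of the molecule stays as it is.

For the measured compounds named here, no pair of measured compounds differs by exactly one change, so no step of known size is available to lean on. Without such a guide, the expectation for compound 3 in this assay is a change of modest size at most, and the step of a number 2.1 percentage points higher from compound 2 to compound 3 (within the scatter) is expected to lie within the scatter, with no direction that can be stated with confidence. On that basis compound 3 is estimated at 17%, with a range from 4% to 32%.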

Compound 3, a percentage reported as inhibition, in the whole organism at one dose (the size of the read-out at that dose, not a potency): 27.3%
Estimate against measurement, compound 3: 10.3 percentage points below; the measured number falls inside the stated range.
By their numbers in this assay, from the lowest: compound 2; then compounds 1 and 3 (each within the scatter of the next).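

In this assay, among the compounds shown here, putting amino in place of hydroxy on a double-bonded nitrogen gives a number 12.4 percentage points higher from compound 2 to compound 3 (beyond the scatter) and is the only change in this set that can be read on its own. It shows that this position responds to the exchange of a single heavy atom, oxygen for nitrogen, even though the counts of hydrogen-bond donors and acceptors are the same for the group that leaves and the group that enters. Nothing measured here accounts for the size or direction of this step, so it stands as an observation without an explanation.

From the compounds shown here alone, it remains open whether the higher number is specific to amino or would also appear with another group on this nitrogen, such as methoxy, methylamino or a longer chain. A single step also leaves open whether the same exchange would move the number in the same direction if the rest of the molecule carried different groups.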